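Swapping the 3-methylphenyl of compound 2 for pyridin-3-yl

This account rests on a few compounds, and the source may have more. Where it says the series, first, only, none or still open, it means among the compounds named here.

Of the compounds shown here, three have been measured in an assay on HEK293 cells for displacement of a labelled ligand from metabotropic glutamate receptor 5 (Homo sapiens), with a stated time of 2 h; on this read-out higher numbers stand for weaker inhibition and lower numbers for stronger inhibition. Compound 1 `CNC(=O)c1ccc(C#Cc2ccccc2)nc1` gives 15000 nM. Compound 2 `Cc1cccc(C#Cc2ccc3c(n2)CCN(C)C3=O)c1` gives 820 nM, the lowest number of the three; its nearest neighbour is compound 3 `COc1cccc(C#Cc2ccc3c(n2)CCN(C)C3=O)c1`, which gives 3660 nM, and the furthest is compound 1, whose number lies well above both. Going by the values given here, the only single-point step among them is a 4.5-fold higher number from compound 2 to compound 3 (0.65 log units; beyond the scatter), a methoxy in place of a methyl on the aromatic carbon of the pendant ring.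

Compound 4 `CN1CCc2nc(C#Cc3cccnc3)ccc2C1=O` differs from compound 2 by pyridin-3-yl in place of 3-methylphenyl on a triple-bonded carbon. Among the compounds with values here, no measured step exchanges the whole pendant ring, so the closest guide is the step from compound 2 to compound 3, which shows that changing this ring costs affinity on this assay. Replacing the carbocycle with a pyridine is a larger alteration than a methoxy for methyl, and a step of comparable or somewhat greater size in the same direction is expected, namely a 4.3-fold higher number from compound 2 to compound 4 (0.63 log units; beyond the scatter). On that basis compound 4 is estimated to give 3500 nM in this assay, within a range from 1000 nM to 12000 nM.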

Compound 4, inhibition constant: 27400 nM
The estimate for compound 4 lay 7.8-fold (0.89 log units) below the measured number, and the stated range ends below it.
By their numbers in this assay, from the lowest: compound 2; then compound 3; then compounds 1 and 4 (each within the scatter of the next).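

In this assay, going by these compounds alone, the pendant ring on the triple-bonded carbon proves much less forgiving than the earlier compounds could show: a 33-fold higher number from compound 2 to compound 4 (1.52 log units; beyond the scatter) is a large step, whereas a 4.5-fold higher number from compound 2 to compound 3 (0.65 log units; beyond the scatter) was only a modest one from the same starting point. A change of the ring itself therefore weighs far more here than the exchange of one substituent for another on the carbon ring. Within the data shown here, the exchange alters two things at once, since pyridin-3-yl brings a ring nitrogen and one hydrogen-bond acceptor and also leaves out the methyl of 3-methylphenyl, so the single step cannot say which of the two carries the loss, and no measurement at hand offers an explanation for its size.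

The compounds shown leave these two parts unseparated: an unsubstituted phenyl on this core would isolate the contribution of the methyl, and a methylpyridinyl would show the effect of the ring nitrogen with the methyl kept in place. Going by these compounds, whether a chloro or a fluoro substituent could stand in for the methyl also remains open.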